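Aryl swap at the ring nitrogen of compound 2

A few compounds are considered here, and "the series" means these few. Any claim that something is new, unique, unknown or untested is made for them only; others in the source may bear on it.

Within the data shown here, compound 2 `N#CC1=C(N)Oc2c(c3nc4ccccc4nc3c3ccccc23)C12C(=O)N(Cc1cnnn1-c1cccc(S(N)(=O)=O)c1)c1ccccc12` gives 21500 nM in a functional assay on HepG2 cells (Homo sapiens) for antiproliferative activity, read by MTT assay, with a stated time of 48 h (on this read-out lower numbers stand for stronger inhibition and higher numbers for weaker inhibition), the only number in the set. Compound 1 `N#CC1=C(N)Oc2c(c3nc4ccccc4nc3c3ccccc23)C12C(=O)N(Cc1cnnn1-c1cccc(Br)c1)c1ccccc12` gives only a limit in this assay, > 50000 nM. Compound 3 `Cc1ccc(C)c(-n2nncc2CN2C(=O)C3(C(C#N)=C(N)Oc4c3c3nc5ccccc5nc3c3ccccc43)c3ccccc32)c1` differs from compound 2 by 2,5-dimethylphenyl in place of 3-sulfamoylphenyl on an aromatic nitrogen. Among the measured compounds shown here, the one measured step bears on this change: an at least 2.3-fold lower number from compound 1 to compound 2 (0.36 log units; beyond the scatter), with compound 1 sitting at the limit of > 50000 nM in this assay, at which 1 of the 2 values shown sits. Removing the sulfamoyl for the 2,5-dimethylphenyl is expected to reverse that gain, a step of a 2.3-fold higher number from compound 2 to compound 3 (0.37 log units; beyond the scatter) in this assay. Compound 3 is therefore expected near 50000 nM, within 20000 nM to 150000 nM, and may well register only as a limit.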

Compound 3, half-maximal inhibitory concentration: > 50000 nM
Compound 3: a limit, no number (the forecaster's own chance of this, stated with the estimate: 45%); the middle value sits exactly at the limit.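

In this assay, 2,5-dimethylphenyl in place of 3-sulfamoylphenyl on the aromatic nitrogen gives an at least 2.3-fold higher number from compound 2 to compound 3 (0.36 log units; beyond the scatter) in this series. A second aryl group without the sulfamoyl now ends at a limit, so among these compounds only compound 2 gives a number: the limit of > 50000 nM in this assay, at which 2 of the 3 values shown sit.

The two limits leave the step between compound 1 and compound 3 unreadable. From the compounds shown here alone, whether a carboxylic acid or an amine on the same phenyl ring would also give a number remains open, as does how far compound 2 can be improved.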